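Replacing cyclohexyl on the nitrogen of compound 3

The compounds below may be only part of what the source reports. "The series", "measured", "known", "first", "only" and "open" are said of these compounds alone.

In an ADME assay on Vero cells (Chlorocebus sabaeus) for cytotoxicity, read by CellTiter-Glo, with a stated time of 72 h (a lower number here means that less compound is tolerated, a higher number that more compound is tolerated), compound 3 `[O-][n+]1nc(NC2CCCCC2)[n+]([O-])c2ccc(Cl)cc21` gives 2.6 ug/mL. Compound 2 `[O-][n+]1nc(NC2CC2)[n+]([O-])c2ccc(Cl)cc21` gives 1.3 ug/mL, within the scatter of compound 3. Compound 1 `COCC(C)Nc1n[n+]([O-])c2cc(F)ccc2[n+]1[O-]` gives 6.3 ug/mL, a number higher than that of compound 3 by more than the scatter, so compound 3 sits in the lower part of this short range.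

The next analogue is compound 4 `COCC(C)Nc1n[n+]([O-])c2cc(Cl)ccc2[n+]1[O-]`, with 1-(methoxymethyl)ethyl in place of cyclohexyl on a nitrogen on an aromatic ring.

Among the measured compounds shown here, only one measured step changes this substituent, a 2.0-fold higher number from compound 2 to compound 3 (0.30 log units; within the scatter), with cyclohexyl in place of cyclopropyl. A change of this group on the shared core has therefore not yet moved this assay beyond the scatter. Compound 1 offers a second clue: it carries the incoming 1-(methoxymethyl)ethyl group on a core that is not identical, and its value is 6.3 ug/mL. That value suggests a modest rise at most, and the core difference limits how far it can be carried over.

A step beyond the scatter is therefore not expected, and the estimated change is a 1.3-fold higher number from compound 3 to compound 4 (0.13 log units; within the scatter). The expected value for compound 4 is 3.5 ug/mL, with an estimated range of 1.5 ug/mL to 8 ug/mL.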

Compound 4, half-maximal cytotoxic concentration: 2.6 ug/mL
For compound 4 the middle estimate is 1.3-fold (0.13 log units) above the measured one, within the range that was stated.
By their numbers in this assay, from the lowest: compounds 2, 3 and 4 (each within the scatter of the next); then compound 1.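

In this assay, the nitrogen on the aromatic ring of the shared core now carries three different groups, and the open-chain 1-(methoxymethyl)ethyl group, with its oxygen and hydrogen-bond acceptor, does not separate from either ring-bearing group: the steps are no change at the digits printed from compound 3 to compound 4 (within the scatter) and a 2.0-fold higher number from compound 2 to compound 4 (0.30 log units; within the scatter). For compounds 2, 3 and 4, this assay therefore does not distinguish cyclopropyl, cyclohexyl and 1-(methoxymethyl)ethyl at this nitrogen, even though the incoming group has no ring. With 1-(methoxymethyl)ethyl held constant, the other place does give a step beyond the scatter, a 2.4-fold lower number from compound 1 to compound 4 (0.38 log units; beyond the scatter), with chloro in place of fluoro on an aromatic carbon, and no measurement available here accounts for either outcome.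

Still open, going by these compounds, is whether a longer chain ending in an amine or a carboxylic acid on the same nitrogen would give a step beyond the scatter from compound 4. Also open, on these data alone, is whether exchanging chloro and fluoro gives a similar step with cyclopropyl or cyclohexyl on the nitrogen.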